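The compounds below may be only part of what the source reports. "The series", "measured", "known", "first", "only" and "open" are said of these compounds alone.

Working notes on the series. Compound 1 `Cn1c(-c2ccc(NC(=O)CCl)cc2)nc(-c2ccccc2)c1-c1ccccc1` is the starting point; in a functional assay on MCF7 cells (Homo sapiens) for cytotoxicity, read by MTT assay, with a stated time of 24 h, tested at 32 ug/mL (on this read-out higher numbers stand for a stronger effect at the one concentration tested and lower numbers for a weaker effect), compound 1 gives 42.8%. Compound 2 `Cc1nnc(SCC(=O)Nc2ccc(-c3nc(-c4ccccc4)c(-c4ccccc4)n3C)cc2)s1` carries the (5-methyl-1,3,4-thiadiazol-2-yl)sulfanyl group in place of chloro on the saturated chain carbon bound to the carbonyl carbon, and in this assay compound 2 gives 83.4%. Among the compounds with values here, the step is a number 40.6 percentage points higher from compound 1 to compound 2 (beyond the scatter), so compound 2 stands highest of the two numbers measured so far, with compound 1 as its only neighbour.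

Compound 3 `Cn1c(-c2ccc(NC(=O)CSC3=NCCS3)cc2)nc(-c2ccccc2)c1-c1ccccc1` is the next member, not yet measured. Its change from compound 2 is a group of 5 heavy atoms (3 carbon, 1 nitrogen, 1 sulfur; one five-membered non-aromatic ring with 2 hetero atoms) in place of a group of 6 heavy atoms (3 carbon, 2 nitrogen, 1 sulfur; one five-membered aromatic ring with 3 hetero atoms), on a sulfur. Within the data shown here, only the step from compound 1 to compound 2 touches this part of the molecule, and it was large; it shows that a ring attached through sulfur at this position is associated with a high number, but it does not separate the aromatic thiadiazole from another five-membered ring. The expectation is therefore a number near that of compound 2, and the step is estimated as a number 11.4 percentage points lower from compound 2 to compound 3 (beyond the scatter), which may lie within the scatter. In this assay compound 3 is estimated at 72%, with a range from 48% to 90%.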

Compound 3, a percentage reported as activity, at one concentration (the size of the read-out at that concentration, not a potency): 52.5%
Beside the measured number, compound 3's estimate is 19.5 percentage points above it; low and high end bracket the measured number.
By their numbers in this assay, from the lowest: compounds 1 and 3 (each within the scatter of the next); then compound 2.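

The exchange on the sulfur gives a number 30.9 percentage points lower from compound 2 to compound 3 (beyond the scatter) in this assay, so a five-membered ring attached through sulfur at this position does not by itself carry the high number, and the identity of that ring counts. Set against the chloro starting point, the five-membered non-aromatic ring with 2 hetero atoms gives a number 9.7 percentage points higher from compound 1 to compound 3 (within the scatter), which means that, among these compounds, the large rise at this position is seen only with the 5-methyl-1,3,4-thiadiazol-2-yl group. Nothing available here accounts for the difference between the two groups on the sulfur.

The two ring groups differ in several features at once, including the methyl group, the ring nitrogen count and the aromatic ring, so the compounds shown do not tell which of these features goes with the step. Also open, as far as these compounds go, is how an unmethylated 1,3,4-thiadiazol-2-yl group on the sulfur, or an amine such as morpholine or a carboxylic acid on the saturated chain carbon in place of the sulfur link, would read in this assay.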